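The source may hold more compounds than are shown below. What is called first, only, known or untested is meant among the compounds shown, and "the series" means these compounds.

Compound 1, `CCCCCCOc1ccc(-n2cnnc2)cc1`, gives 9.8 mg/kg in a functional assay on the whole organism (strain C57B/6) with Mus musculus as the target, in the maximal electroshock model; a lower number here means that less compound is needed, a higher number that more compound is needed for the effect. Compound 2, `CCCCCCOc1ccc(-n2cnnc2CCCCCC)cc1`, reaches only a limit of this assay, > 40 mg/kg. Compound 3, `CCCCCCCCCc1nncn1-c1ccc(OCCCCCC)cc1`, likewise stops at a limit, > 40 mg/kg.

Among the measured compounds shown here, compound 1 holds the only real number among the three; the other two values are limits, (the limit of > 40 mg/kg in this assay, at which 2 of the 3 values shown sit). The step followed here leads to compound 4, `CCCCCCOc1ccc(-n2cnnc2-c2ccc(OC)cc2)cc1`: 4-methoxyphenyl in place of hydrogen on an aromatic carbon. For the measured compounds named here, two measured steps touch the same aromatic carbon: an at least 4.0-fold higher number from compound 1 to compound 2 (0.61 log units; beyond the scatter) and an at least 4.0-fold higher number from compound 1 to compound 3 (0.61 log units; beyond the scatter). Both place a group where compound 4 gains its 4-methoxyphenyl, and both pushed the number at least modestly upward. The same direction is expected for compound 4, a rise of a 4.1-fold higher number from compound 1 to compound 4 (0.61 log units; beyond the scatter). The estimate for compound 4 is 40 mg/kg, between 15 mg/kg and 100 mg/kg.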

Compound 4, dose for half-maximal effect: 15.8 mg/kg
Compound 4: the middle estimate sits 2.5-fold (0.40 log units) above what was measured; low and high end bracket the measured number.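

In this assay, this aromatic carbon tolerates a large group after all: 4-methoxyphenyl in place of hydrogen gives a 1.6-fold higher number from compound 1 to compound 4 (0.21 log units; within the scatter). What enters therefore matters, not just that something enters, since 4-methoxyphenyl in place of the chains gives an at least 2.5-fold lower number from compound 3 to compound 4 (0.40 log units; beyond the scatter) for nonyl and an at least 2.5-fold lower number from compound 2 to compound 4 (0.40 log units; beyond the scatter) for hexyl. Compound 2 and compound 3 remain limits, not numbers: the limit of > 40 mg/kg in this assay, at which 2 of the 4 values shown sit.

Open, going by these compounds, is whether a plain phenyl without the methoxy, or a small methyl group, on this carbon would behave like 4-methoxyphenyl or like the chains.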